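The source may report more compounds than this note shows. Statements on the series, on what has been measured and on what is new or still open speak of the compounds shown alone.

Measured compounds:
Compound 1 `C=C1C(=O)[C@]23C[C@@]1(O)CC[C@H]2c1ccc(OS(=O)(=O)c2ccc(C)cc2)c(C)c1[C@@H]3Cn1cc(-c2ccc(Cl)cc2)nn1`: in a functional assay on HL-60 cells (Homo sapiens) for cytotoxicity, read by MTT assay, with a stated time of 4 days (a higher number here means a weaker inhibitor, a lower number a stronger inhibitor), compound 1 gives 1260 nM.
Compound 2 `C=C1C(=O)[C@]23C[C@@]1(O)CC[C@H]2c1ccc(O)c(C)c1[C@@H]3Cn1cc(-c2ccc(F)cc2)nn1`: in this assay compound 2 gives 660 nM.

Compound 2 holds the lower of the two numbers, but its gap to compound 1 lies within the usual scatter, so the two measured compounds are not separated by these data. Among the compounds with values here, compound 1 and compound 2 also differ in more than one place, so no single step between measured compounds can be read from the pair.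

Compound 3 `C=C1C(=O)[C@]23C[C@@]1(O)CC[C@H]2c1ccc(OS(=O)(=O)c2ccc(C)cc2)c(C)c1[C@@H]3Cn1cc(-c2ccc(F)cc2)nn1` is not yet measured. It differs from compound 2 by (4-methylphenyl)sulfonyl in place of hydrogen on an oxygen on an aromatic ring. Within the data shown here, no measured pair isolates this change. Compound 1, which carries the same (4-methylphenyl)sulfonyl group on the ring oxygen, gives 1260 nM, and that number sits on the higher side of compound 2 without leaving the scatter. The expectation is therefore a small step in this assay toward a higher number, of a size that may not exceed the scatter, as a 1.5-fold higher number from compound 2 to compound 3 (0.18 log units; within the scatter). Compound 3 is estimated at 1000 nM, with a range from 400 nM to 2500 nM.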

Compound 3, half-maximal inhibitory concentration: 1290 nM
Estimate against measurement, compound 3: 1.3-fold (0.11 log units) below, within the range that was stated.
By their numbers in this assay, from the lowest: compounds 2, 1 and 3 (each within the scatter of the next).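

Working notes on the ring oxygen: in this assay the step of a 2.0-fold higher number from compound 2 to compound 3 (0.29 log units; within the scatter) is the first reading that isolates (4-methylphenyl)sulfonyl in place of hydrogen at this position, and it does not separate the sulfonylated oxygen from the free hydroxy. The aromatic halogen can now also be read alone, with the sulfonyl group held constant: fluoro in place of chloro on an aromatic carbon gives a 1.0-fold higher number from compound 1 to compound 3 (0.01 log units; within the scatter) and leaves the two compounds indistinguishable in this assay. Neither single change therefore leaves the scatter among these three compounds, and nothing in the series so far accounts for how little either change registers.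

Open questions remain at both places, since the ring oxygen has been seen only as the free hydroxy and with the large sulfonyl group, leaving a small methyl ether, an acetyl ester or a chain ending in an amine unread. On the phenyl ring of the triazole substituent, only fluoro and chloro appear, so a methoxy group or a carboxylic acid at that carbon could still show whether this position responds at all.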